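Hydantoin-fused naphthoquinone series: terminal amino on the butyl chain

The source may report more compounds than this note shows. Statements on the series, on what has been measured and on what is new or still open speak of the compounds shown alone.

Measured so far in a functional assay on SW-620 cells (Homo sapiens) for inhibition; a higher number here means a weaker inhibitor, a lower number a stronger inhibitor:
compound 1 `CN1C(=O)NC2(CSC3=C2C(=O)c2ccccc2C3=O)C1=O` gives 108 nM
compound 2 `CCCCN1C(=O)NC2(CSC3=C2C(=O)c2ccccc2C3=O)C1=O` gives 740 nM
compound 3 `O=C1C2=C(C(=O)c3ccccc31)C1(CS2)NC(=O)N(CCO)C1=O` gives 198 nM

Compound 2 stands highest of the three in this assay, with compound 3 nearest and compound 1 furthest. The next step goes from compound 2 to compound 4 `NCCCCN1C(=O)NC2(CSC3=C2C(=O)c2ccccc2C3=O)C1=O`: amino in place of hydrogen on a saturated chain carbon, four bonds along the chain from an amide-type nitrogen in a ring. Within the data shown here, two measured steps bear on it. The step of a 6.9-fold higher number from compound 1 to compound 2 (0.84 log units; beyond the scatter) shows that lengthening the chain on the amide-type nitrogen raised the number; the step of a 3.7-fold lower number from compound 2 to compound 3 (0.57 log units; beyond the scatter) shows that a hydroxy at the end of a shorter chain brought it back down, so that compound 3 sits within the scatter of compound 1. A terminal amino on the longer chain is expected to act in the same direction, giving a modest lower number, a 2.5-fold lower number from compound 2 to compound 4 (0.39 log units; beyond the scatter). Compound 4 is therefore estimated at 300 nM, in the range 100 nM to 900 nM.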

Compound 4, half-maximal inhibitory concentration: 68 nM
Compound 4: the middle estimate sits 4.4-fold (0.64 log units) above what was measured; measured number below the stated range.
By their numbers in this assay, from the lowest: compounds 4, 1 and 3 (each within the scatter of the next, the first and the last beyond it); then compound 2.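

The terminal amino on the butyl chain cancels the rise that came with that chain, giving an 11-fold lower number from compound 2 to compound 4 (1.04 log units; beyond the scatter) and leaving a 1.6-fold lower number from compound 1 to compound 4 (0.20 log units; within the scatter) so a long chain on this nitrogen is not by itself tied to a high number. The amino-ended chain also parts from the shorter hydroxy-ended chain, with a 2.9-fold lower number from compound 3 to compound 4 (0.46 log units; beyond the scatter) though end group and chain length change together in that step. Nothing at hand explains these changes.

Open, as far as these compounds go, is how a hydroxy at the end of the butyl chain would compare, which would separate end group from chain length. Also open, from the compounds shown here alone, are a shorter 2-aminoethyl chain and a carboxylic acid at the chain end.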